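Swapping fluoro for benzoyl on a weakly active core

This account rests on a few compounds, and the source may have more. Where it says the series, first, only, none or still open, it means among the compounds named here.

Measured compounds:
- compound 1, `COc1cc(Cn2cc(COc3cccc(/C=C4/C(=O)Nc5ccccc54)c3)nn2)cc(OC)c1`: in a functional assay on BT-549 cells (Homo sapiens) for inhibition, read by MTT assay, with a stated time of 48 h (a higher number here means a weaker inhibitor, a lower number a stronger inhibitor), compound 1 gives "not determined" (no result reported)
- compound 2, `O=C1Nc2ccc(Cl)cc2/C1=C/c1cccc(OCc2cn(Cc3ccccc3)nn2)c1`: in this assay compound 2 gives "not determined" (no result reported)
- compound 3, `O=C1Nc2ccc(F)cc2/C1=C\c1cccc(OCc2cn(Cc3ccccc3)nn2)c1`: > 50000 nM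

Only compound 3 carries a number in this assay, and that number is a limit rather than a measured value. Compound 3 therefore stands at the edge of what the assay can report, as the line the limit of > 50000 nM in this assay, at which 1 of the 3 values shown sits, shows. Compound 4, `O=C1Nc2ccc(C(=O)c3ccccc3)cc2/C1=C\c1cccc(OCc2cn(Cc3ccccc3)nn2)c1`, is not yet measured; it differs from compound 3 in one place: benzoyl in place of fluoro on an aromatic carbon. Among the compounds with values here, with no measured step to compare against, the expected change in potency from compound 3 to compound 4 is an at least 1.6-fold lower number from compound 3 to compound 4 (0.22 log units; that floor lies within the scatter), a shift that may or may not exceed the usual scatter. Compound 4 is estimated at 30000 nM, within a range from 5000 nM to 100000 nM, and a limit-only result remains quite possible.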

Compound 4, half-maximal inhibitory concentration: > 50000 nM
Compound 4 gave a limit, no number; the forecaster's own chance of this, stated with the estimate: 50%; middle value at least 1.6-fold (0.22 log units) from the limit.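

In this assay, within the data shown here, compound 3 and compound 4 both give only a limit, and no step between them can be read. The compounds shown leave open whether swapping fluoro for benzoyl changes potency at all, and how potent any of them is.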